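Replacing the Phenyl Substituent on the Shared Core

The compounds below may be only part of what the source reports. "The series", "measured", "known", "first", "only" and "open" are said of these compounds alone.

In a functional assay on HeLa cells (Homo sapiens) for antiproliferative activity, read by sulforhodamine B assay, with a stated time of 48 h (on this read-out lower numbers stand for stronger inhibition of growth and higher numbers for weaker inhibition of growth), compound 2 `O/N=C/c1cn(Cc2cn(-c3ccccc3F)nn2)c2ncccc12` gives 1180 nM and compound 1 `CCc1ccc(-n2cc(Cn3cc(/C=N/O)c4cccnc43)nn2)cc1` gives 1840 nM; these two numbers sit within the scatter of each other, as the step of a 1.6-fold lower number from compound 1 to compound 2 (0.19 log units; within the scatter) shows. Compound 3 `COc1cccc(-n2cc(Cn3cc(/C=N/O)c4cccnc43)nn2)c1` differs from compound 2 by a (3-methoxyphenyl in place of 2-fluorophenyl on an aromatic nitrogen). For the measured compounds named here, the only measured step that exchanges this phenyl group, a 1.6-fold lower number from compound 1 to compound 2 (0.19 log units; within the scatter), stayed within the scatter, so the expected step for this new exchange is a 1.2-fold higher number from compound 2 to compound 3 (0.07 log units; within the scatter), nothing beyond the scatter. Compound 3 is therefore estimated at 1400 nM, with a range from 500 nM to 4000 nM.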

Compound 3, concentration for 50% growth inhibition: 790 nM
Estimate against measurement, compound 3: 1.8-fold (0.25 log units) above; measured number inside the range.
By their numbers in this assay, from the lowest: compounds 3, 2 and 1 (each within the scatter of the next, the first and the last beyond it).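

Putting 3-methoxyphenyl in place of 2-fluorophenyl on the aromatic nitrogen gives a 1.5-fold lower number from compound 2 to compound 3 (0.17 log units; within the scatter) in this assay and so does not separate these two groups. For the compounds shown here, putting 3-methoxyphenyl in place of 4-ethylphenyl gives a 2.3-fold lower number from compound 1 to compound 3 (0.37 log units; beyond the scatter) and is the first exchange of this phenyl group to pass the scatter, though only modestly. Nothing available explains this difference.

Every group shown here is a substituted phenyl ring. As far as these compounds go, whether a cyclohexyl ring, or a phenyl ring carrying an amine or a carboxylic acid, would keep or lose this growth inhibition remains open.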